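One Aryl Swap on a Weakly Active Compound

The source may hold more compounds than are shown below. What is called first, only, known or untested is meant among the compounds shown, and "the series" means these compounds.

Compound 1 `Cc1c(-c2cc(Cl)cc(Cl)c2)c(C(=O)O)nn1-c1nc(-c2cnn(C)c2)c(SC(C)C)s1` is reported in a functional assay on BJAB cells (Homo sapiens) for antiproliferative activity, with a stated time of 4 days (on this read-out higher numbers stand for an effect only at larger amounts of compound and lower numbers for an effect already at smaller amounts), as "not active" (no number reported), with no number attached. Among the measured compounds shown here, compound 2 `Cc1cc(C#N)cc(-c2c(C)nn(-c3nc(-c4ccc(Cl)c(Cl)c4)c(SC(C)C)s3)c2C(=O)O)c1` gives 4800 nM in this assay, the only number available, so it stands alone as the sole measured point. Compound 3 `Cc1nn(-c2nc(-c3ccc(Cl)c(Cl)c3)c(SC(C)C)s2)c(C(=O)O)c1-c1ccccc1C(F)(F)F` differs from compound 2 by 2-(trifluoromethyl)phenyl in place of 3-cyano-5-methylphenyl on an aromatic carbon. For the measured compounds named here, no measured pair shows what such a swap does, so the expected step is a 1.5-fold higher number from compound 2 to compound 3 (0.16 log units; within the scatter), close to the scatter and leaning toward a weaker effect. For compound 3 the expected value is 7000 nM, within a range of 2000 nM to 25000 nM.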

Compound 3, half-maximal effective concentration: 5200 nM
For compound 3 the middle estimate is 1.3-fold (0.13 log units) above the measured one, and the stated range covers the measured number.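

Putting 2-(trifluoromethyl)phenyl in place of 3-cyano-5-methylphenyl on this aromatic carbon gives, in this assay, a 1.1-fold higher number from compound 2 to compound 3 (0.03 log units; within the scatter). This position therefore carries either substituted phenyl ring with no difference beyond the usual scatter, so the nitrile and methyl groups are not needed for this level of effect in this pair. Nothing available here explains this match.

Still open, from the compounds shown here alone, is what an unsubstituted phenyl ring or a simple amine on this carbon would give. Also open, going by these compounds, is whether an amide in place of the carboxy group would change the read-out.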